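The source may report more compounds than this note shows. Statements on the series, on what has been measured and on what is new or still open speak of the compounds shown alone.

Working notes on the series in an assay on isolated protein for inhibition of ribosomal protein S6 kinase alpha-1 (Homo sapiens), read by mobility shift assay, tested at 30 uM; on this read-out lower numbers stand for less inhibition and higher numbers for more inhibition at the one concentration tested (going by the name of the read-out). Of the compounds shown here, three have numbers so far. Compound 1 `COC(=O)CCc1c(C)[nH]c(=O)c2c(N)nn(C)c12` gives -5%, compound 2 `CC(=O)Nc1nn(C)c2cc(-c3ccc(N4CCN(C)CC4)cc3)[nH]c(=O)c12` gives 16%, and compound 3 `Nc1c2c(=O)[nH]c(-c3ccccc3)cc2nn1-c1ccccc1` gives 38%. Compound 3 stands highest of the three: compound 2 is its nearest neighbour, at a gap beyond the scatter, and compound 1 is furthest, also beyond the scatter. Among the measured compounds shown here, none of these three pairs differ in a single place, so the measured set offers no single-change step to lean on.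

Compound 4 `COc1ccc(-c2cc3nn(-c4ccccc4)c(N)c3c(=O)[nH]2)cc1` has not yet been measured in this assay. It differs from compound 3 in one place: methoxy in place of hydrogen on an aromatic carbon. For the measured compounds named here, with no comparable step among the measured compounds, the expectation rests on the value of compound 3 alone, 38%, and on the small size of the added group. The step of a number 4 percentage points higher from compound 3 to compound 4 (within the scatter) is expected to be small, within the scatter, with no firm direction. Compound 4 is therefore estimated at 42%, within a range from 20% to 62%.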

Compound 4, a percentage reported as inhibition, at one concentration (the size of the read-out at that concentration, not a potency): 4%
Beside the measured number, compound 4's estimate is 38 percentage points above it, and the stated range ends above it.
By their numbers in this assay, from the lowest: compounds 1 and 4 (each within the scatter of the next); then compound 2; then compound 3.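

In this assay, the series now has its first single-change step, and it is large: methoxy in place of hydrogen on an aromatic carbon, para to a large group, gives a number 34 percentage points lower from compound 3 to compound 4 (beyond the scatter) in this read-out. The earlier compounds shown here differ from one another in more than one place, so they could not show that phenyl to 4-methoxyphenyl alone, an addition of only 2 heavy atoms, is enough to move the number beyond the scatter. This place on the phenyl is therefore sensitive to substitution, at least for this one group. Nothing at hand explains the size of this step.

As far as these compounds go, whether the loss belongs to methoxy in particular or to any group at this carbon stays open; fluorine, hydroxyl or an amine there would separate the two. Also open, from the compounds shown here alone, is whether the other carbons of that ring respond in the same way.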